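This account rests on a few compounds, and the source may have more. Where it says the series, first, only, none or still open, it means among the compounds named here.

Measured compounds:
- compound 1 `CC(C)C(=O)N1CCCCC1c1nnn(-c2cccc(Cl)c2)n1`, in an assay on cell membranes for displacement of a labelled ligand from metabotropic glutamate receptor 5 (Rattus norvegicus); a higher number here means a weaker inhibitor, a lower number a stronger inhibitor: 138 nM
- compound 2 `O=C(c1ccc(Br)o1)N1CCCCC1c1nnn(-c2cccc(Cl)c2)n1`, in this assay: 49 nM

Within the data shown here, compound 2 gives the lowest of the two numbers in this assay; its only neighbour is compound 1, and the single measured step, a 2.8-fold lower number from compound 1 to compound 2 (0.45 log units; beyond the scatter), separates the two. Compound 3 `O=C(c1ccco1)N1CCCCC1c1nnn(-c2cccc(Cl)c2)n1` is not yet measured. It differs from compound 2 by hydrogen in place of bromo on an aromatic carbon. Among the measured compounds shown here, no measured step alters a substituent on the five-membered ring, so the step from compound 1 to compound 2, which exchanges the whole group on the carbonyl carbon, bears on it only loosely: it shows that the group on the carbonyl carbon shifts the number to a modest degree. Removing bromo is a narrower change than that exchange, and the expected step is a 1.7-fold higher number from compound 2 to compound 3 (0.24 log units; within the scatter), a modest rise in the number, possibly none beyond the scatter. Compound 3 is therefore expected to give 85 nM in this assay, with a range from 30 nM to 250 nM.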

Compound 3, inhibition constant: 126 nM
Beside the measured number, compound 3's estimate is 1.5-fold (0.17 log units) below it; low and high end bracket the measured number.
By their numbers in this assay, from the lowest: compound 2; then compounds 3 and 1 (each within the scatter of the next).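

In this assay, hydrogen in place of bromo on the aromatic carbon next to the ring oxygen gives a 2.6-fold higher number from compound 2 to compound 3 (0.41 log units; beyond the scatter) at this single position, a step beyond the scatter. The step of a 1.1-fold lower number from compound 1 to compound 3 (0.04 log units; within the scatter) shows that furan-2-yl and isopropyl on the carbonyl carbon are not separated, so among these three compounds the lower number of compound 2 goes with the bromo and not with the furan ring as such. Nothing at hand explains this step.

Going by these compounds, whether bromo is special at this carbon remains open: chloro, methyl or an amine in the same place would each test that. On these data alone, it is also open whether the step carries over when the shared core is changed elsewhere.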